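Swapping the Sulfonyl Aryl Group of Compound 1

The source may hold more compounds than are shown below. What is called first, only, known or untested is meant among the compounds shown, and "the series" means these compounds.

Of the compounds shown here, three of a shared core have been measured in a functional assay on MIA PaCa-2 cells (Homo sapiens) for inhibition, read by MTT assay, with a stated time of 72 h; on this read-out lower numbers stand for stronger inhibition of growth and higher numbers for weaker inhibition of growth. Compound 1, with the structure `O=S(=O)(NCCCCCCNCc1ccc(Br)cc1)c1ccc2c(c1)OCC2`, gives 13000 nM in this assay, the highest of the three numbers. Compound 2, with the structure `O=S(=O)(NCCCNCc1ccccc1)c1cc(C(F)(F)F)cc(C(F)(F)F)c1`, gives 11000 nM, a value that lies within the usual scatter of the number for compound 1, so the two cannot be told apart. Compound 3, with the structure `O=S(=O)(NCCCCCCNCc1ccc(Br)cc1)c1c(Cl)cc(C(F)(F)F)cc1Cl`, gives 5670 nM, which sits beyond the scatter on the side of stronger inhibition of growth relative to compound 1.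

The next compound, compound 4, with the structure `O=[N+]([O-])c1ccccc1S(=O)(=O)NCCCCCCNCc1ccc(Br)cc1`, differs from compound 1 in one place: a group of 9 heavy atoms (6 carbon, 1 nitrogen, 2 oxygen; one six-membered aromatic ring of carbon only) in place of a group of 9 heavy atoms (8 carbon, 1 oxygen; one five-membered non-aromatic ring with 1 hetero atom, one six-membered aromatic ring of carbon only), on a sulfonyl sulfur. Among the compounds with values here, no measured pair shows what this particular exchange on the sulfonyl sulfur does to the read-out, and the change from compound 1 to compound 3, which alters the same position with a different group, is the only hint that the aryl group on the sulfonyl sulfur can move the number at all.

On that basis compound 4 is expected to land close to compound 1, with a step from compound 1 to compound 4 of a 1.3-fold lower number from compound 1 to compound 4 (0.11 log units; within the scatter), which is not beyond the scatter. The estimate for compound 4 is 10000 nM, with a likely range from 4000 nM to 30000 nM.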

Compound 4, concentration for 50% growth inhibition: 11700 nM
Beside the measured number, compound 4's estimate is 1.2-fold (0.07 log units) below it, within the range that was stated.
By their numbers in this assay, from the lowest: compounds 3, 2, 4 and 1 (each within the scatter of the next, the first and the last beyond it).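

In this assay, putting 2-nitrophenyl on the sulfonyl sulfur in place of the group carried by compound 1 gives a 1.1-fold lower number from compound 1 to compound 4 (0.05 log units; within the scatter) and so leaves the read-out where it stood. Within the data shown here, this is the first step measured at this position, and it shows that, with the rest of compound 1 held fixed, the five-membered non-aromatic ring can be given up for a nitro-bearing phenyl group without a change that can be told from the scatter. No measurement shown here accounts for this result.

From the compounds shown here alone, what stays open is whether the flat outcome holds for other groups on the sulfonyl sulfur, such as a phenyl ring with an amine or a carboxylic acid in place of the nitro group, or a 3-nitrophenyl or 4-nitrophenyl group. Going by these compounds, it is equally open whether 2-nitrophenyl would behave the same way on a shorter or longer chain, or with a group other than the 4-bromobenzyl group on the far amine.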